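The compounds below may be only part of what the source reports. "The series", "measured", "known", "first", "only" and "open" are said of these compounds alone.

Compound 1 `Cc1cn(C)nc1Nc1cc2c(c(N)n1)c(C#N)c(N1CCC[C@H]1C)n2C`: 63 nM
Compound 2 `CN(C)c1c(C#N)c2c(N)ncnc2n1C`: 111 nM
Compound 3 `C[C@@H]1CCCN1c1c(C#N)c2c(N)nc(N)nc2n1C`: 6 nM

These numbers come from an assay on isolated protein for binding affinity to Leucine-rich repeat serine/threonine-protein kinase 2 (Homo sapiens), read by TR-FRET and LanthaScreen, with a stated time of 2 h; on this read-out lower numbers stand for stronger inhibition and higher numbers for weaker inhibition. Among the three, compound 2 gives the highest number; compound 1 sits within the scatter of it, so the two cannot be ordered, while compound 3 stands beyond the scatter at the lower end.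

Compound 4 `Cn1c(N)c(C#N)c2c(N)ncnc21` has not yet been measured in this assay. It differs from compound 2 by one change: amino in place of dimethylamino on an aromatic carbon. Going by the values given here, no measured pair in this set shows this exact change, so the direction rests on no direct precedent. A shift toward a higher number, small and probably within the scatter, is expected, which is what a 1.8-fold higher number from compound 2 to compound 4 (0.26 log units; within the scatter) means. For compound 4 the estimate is 200 nM, in a range from 60 nM to 700 nM.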

Compound 4, inhibition constant: 346 nM
Beside the measured number, compound 4's estimate is 1.7-fold (0.24 log units) below it, within the range that was stated.
By their numbers in this assay, from the lowest: compound 3; then compounds 1 and 2 (each within the scatter of the next); then compound 4.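

In this assay, going by these compounds alone, amino in place of dimethylamino gives a 3.1-fold higher number from compound 2 to compound 4 (0.49 log units; beyond the scatter), the first step beyond the scatter at this aromatic carbon. The group here therefore affects binding: this replacement, which removes both carbons and adds a hydrogen-bond donor, weakens it. No available evidence explains this shift. A methylamino group, with one methyl kept on the nitrogen, could show whether the number changes gradually between these two groups. Going by these compounds, whether the same swap has a similar effect on the cores of compound 1 and compound 3 also remains open.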